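A few compounds are considered here, and "the series" means these few. Any claim that something is new, unique, unknown or untested is made for them only; others in the source may bear on it.

Compound 1 `CCOc1cc(=O)oc2cc(OCc3cccc(Cl)c3)ccc12` is the weaker-looking of the two measured entries in an assay on isolated protein (strain Sprague-Dawley) for inhibition of Amine oxidase [flavin-containing] A (Rattus norvegicus), read by spectrophotometry, with a stated time of 5 min, tested at 10 uM; a lower number here means less inhibition, a higher number more inhibition at the concentration tested (going by the name of the read-out): in this assay compound 1 gives 2%, the lowest of the two numbers, though its nearest neighbour lies within the scatter. That neighbour is compound 2 `CCOc1cc(=O)oc2cc(OCc3cccc(Br)c3)ccc12`, which in this assay gives 2.5%; the step of a number 0.5 percentage points higher from compound 1 to compound 2 (within the scatter) (bromo in place of chloro on an aromatic carbon) is within the scatter, so the two compounds cannot be told apart on these numbers.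

Compound 3 `CC(C)Oc1cc(=O)oc2cc(OCc3cccc(Cl)c3)ccc12` differs from compound 1 by methyl in place of hydrogen on a saturated chain carbon bound to an oxygen on an aromatic ring and a saturated chain carbon. Within the data shown here, no measured step touches this part of the core; the single step available concerns a halogen on the aromatic ring and was within the scatter. With nothing to suggest otherwise, the step is expected to be a number 1 percentage points higher from compound 1 to compound 3 (within the scatter), that is, none beyond the scatter. Compound 3 is therefore estimated at 3%, with a range from 0% to 12%.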

Compound 3, a percentage reported as inhibition, at one concentration (the size of the read-out at that concentration, not a potency): 3%
The estimate for compound 3 equals the measured number at the digits printed; the range from low to high includes it.
By their numbers in this assay, from the lowest: compounds 1, 2 and 3 (each within the scatter of the next).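

Read in this assay, methyl in place of hydrogen on a saturated chain carbon bound to an oxygen on an aromatic ring and a saturated chain carbon gives a number 1 percentage points higher from compound 1 to compound 3 (within the scatter), so ethoxy and isopropoxy cannot be told apart on these numbers. The earlier step reached only the halogen on the aromatic ring, whereas this one shows that the same holds for this single added methyl on the alkoxy chain, with inhibition remaining slight in all three compounds at the concentration tested. No independent measurement bears on this result.

From the compounds shown here alone, whether a longer chain such as butoxy in place of ethoxy would give a reading beyond the scatter remains open. The same question stands for an amine or a carboxylic acid carried on that chain.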